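Swapping the amide aryl group: methoxyphenyl to dichlorophenyl

A few compounds are considered here, and "the series" means these few. Any claim that something is new, unique, unknown or untested is made for them only; others in the source may bear on it.

Measured so far in a functional assay on HCT-116 cells (Homo sapiens) for antiproliferative activity, read by MTT assay, with a stated time of 48 h; on this read-out lower numbers stand for stronger inhibition and higher numbers for weaker inhibition:
- compound 1 `O=C(/C=C/c1cccc(NC(=O)c2ccccc2Br)c1)c1nc2ccccc2[nH]1` gives 1680 nM
- compound 2 `Cc1ccc(C(=O)Nc2cccc(/C=C/C(=O)c3nc4ccccc4[nH]3)c2)cc1` gives 1660 nM
- compound 3 `COc1cccc(C(=O)Nc2cccc(/C=C/C(=O)c3nc4ccccc4[nH]3)c2)c1` gives 3680 nM

All three share one core and differ only in the aryl group attached to the amide carbonyl carbon. Compound 3 stands at the highest number of the three, meaning the weakest inhibition in this assay. The steps that reach it are a 2.2-fold higher number from compound 1 to compound 3 (0.34 log units; beyond the scatter) and a 2.2-fold higher number from compound 2 to compound 3 (0.35 log units; beyond the scatter), both modest but beyond the scatter, while a 1.0-fold lower number from compound 1 to compound 2 (0.01 log units; within the scatter) shows the bromo and methyl variants within the scatter of each other.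

Compound 4 `O=C(Nc1cccc(/C=C/C(=O)c2nc3ccccc3[nH]2)c1)c1cc(Cl)cc(Cl)c1` takes the next step: 3,5-dichlorophenyl in place of 3-methoxyphenyl on a carbonyl carbon. For the measured compounds named here, no measured step covers a dichlorophenyl group, so the expectation leans on the two steps into compound 3, which point to the methoxy-bearing ring sitting on the weaker side of this small set. Compound 4 is therefore expected to return to roughly the level of compounds 1 and 2, a step of a 1.8-fold lower number from compound 3 to compound 4 (0.26 log units; within the scatter). The estimate for compound 4 in this assay is 2000 nM, in a range from 700 nM to 6000 nM.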

Compound 4, half-maximal inhibitory concentration: 1650 nM
For compound 4 the middle estimate is 1.2-fold (0.08 log units) above the measured one; the range from low to high includes it.
By their numbers in this assay, from the lowest: compounds 4, 2 and 1 (each within the scatter of the next); then compound 3.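

In this assay the change on the carbonyl carbon gives a 2.2-fold lower number from compound 3 to compound 4 (0.35 log units; beyond the scatter) and so shows that a ring with two chlorines and no hydrogen-bond acceptor does not share the higher number of the 3-methoxyphenyl ring. Both a 1.0-fold lower number from compound 2 to compound 4 (0.00 log units; within the scatter) and a 1.0-fold lower number from compound 1 to compound 4 (0.01 log units; within the scatter) put 3,5-dichlorophenyl level with 4-methylphenyl and 2-bromophenyl, so three differently substituted rings now sit within the scatter of one another and only compound 3 stands apart. No measurement shown here explains why compound 3 alone differs.

The compounds shown leave open whether the methoxy group itself is what sets compound 3 apart. They also leave open how a ring carrying an amine or a carboxylic acid, or a longer chain in place of the ring, would read on this carbonyl carbon.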